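Notes on the shared core: compound 2 toward compound 4

The source may hold more compounds than are shown below. What is called first, only, known or untested is meant among the compounds shown, and "the series" means these compounds.

Compound 1 `O=C(Nc1ccccc1)c1cccc(/C=C2\CC(=O)N(c3ccccc3)C2=O)c1` in an ADME assay on SW480 cells (Homo sapiens) for cytotoxicity, read by MTT assay, with a stated time of 72 h (a lower number here means a stronger inhibitor, a higher number a weaker inhibitor), gives > 100000 nM, which is a limit of the assay and not a number. Compound 2 `CCc1ccc(NC(=O)c2cccc(/C=C3\CC(=O)N(c4ccccc4)C3=O)c2)cc1` in this assay gives > 100000 nM, likewise a limit and not a number. Compound 3 `CCc1cccc(NC(=O)c2cccc(/C=C3\CC(=O)N(Cc4ccccc4)C3=O)c2)c1` in this assay gives 91500 nM. The step that the two limits leave unreadable from compound 1 to compound 2 is ethyl in place of hydrogen on an aromatic carbon; its size cannot be read because of the limit of > 100000 nM in this assay, at which 2 of the 3 values shown sit. Compound 2 thus stands only at a limit, with one further value shown also a limit, and nothing places it within the numbered range.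

Compound 4 `O=C(Nc1ccc(OC(F)F)cc1)c1cccc(/C=C2\CC(=O)N(c3ccccc3)C2=O)c1` differs from compound 2 by difluoromethoxy in place of ethyl on an aromatic carbon, para to a large group. Within the data shown here, no measured step covers this exchange, and the one step touching compound 2 is unreadable. No shift beyond the scatter is expected in this assay, so compound 4 is estimated at 100000 nM, with a range from 50000 nM to 200000 nM. The expected step is then a number no higher from compound 2 to compound 4 (the limit leaves the size open), a flat one.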

Compound 4, half-maximal inhibitory concentration: > 100000 nM
Compound 4 ended at the assay's limit (the forecaster's own chance of this, stated with the estimate: 70%); the middle value lies on the limit itself.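

Neither step into compound 4, from compound 1 or from compound 2, can be read, since all three compounds stand at a limit and not a number: the limit of > 100000 nM in this assay, at which 3 of the 4 values shown sit.

In this assay the compounds shown leave open what shift, if any, separates hydrogen, ethyl and difluoromethoxy at this place.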